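Limits only: from compound 2 to compound 4

The source may hold more compounds than are shown below. What is called first, only, known or untested is meant among the compounds shown, and "the series" means these compounds.

In an ADME assay on MT2 cells (Homo sapiens) for cytotoxicity, read by XTT assay, with a stated time of 4 days (a higher number here means that more compound is tolerated, a lower number that less compound is tolerated), compound 2 (`Cc1nc(C(NC(=O)C(=O)Nc2ccc(Cl)cc2)C2CCNCC2)sc1CCO`) stands at > 78500 nM and this value is a limit of the assay. Compound 1 (`Cc1nc(C(NC(=O)C(=O)Nc2ccc(Cl)cc2)C2CCNCC2)sc1CO`) gives > 81000 nM which is also a limit. Compound 3 (`Cc1nc(C(NC(=O)C(=O)Nc2ccc(Cl)cc2)C2CCCCN2)sc1CO`) gives > 108000 nM and this too is a limit. For the measured compounds named here, no measured compound in this set therefore has a number to serve as a reference.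

Compound 4 (`Cc1nc(C(NC(=O)C(=O)Nc2ccc(Cl)cc2)C2CCCCN2C)sc1CCO`) has 1-methylpiperidin-2-yl in place of piperidin-4-yl on a saturated chain carbon bound to an amide-type nitrogen and an aromatic carbon. The nearest measured change, piperidin-2-yl in place of piperidin-4-yl, is a step that the two limits leave unreadable from compound 1 to compound 3 and offers no size. The change in the chain is a step that the two limits leave unreadable from compound 1 to compound 2 and offers no size either. Going by the values given here, no measured compound carries the 1-methylpiperidin-2-yl group.

With only these limits as a guide, no step beyond the scatter is expected in this assay and no direction can be given. The expected step is a step that the limit leaves unreadable from compound 2 to compound 4 as an estimate with wide uncertainty. For compound 4 the estimated value is 80000 nM with an expected range from 25000 nM to 130000 nM. A limit is expected again for compound 4.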

Compound 4, half-maximal cytotoxic concentration: 88000 nM
For compound 4 the middle estimate is 1.1-fold (0.04 log units) below the measured one; the range from low to high includes it.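

In this assay compound 2 stands at > 78500 nM, which is a limit of the assay. The pair of compound 2 and compound 4 yields no readable step. The compounds shown leave open the size and direction of any effect of 1-methylpiperidin-2-yl in place of piperidin-4-yl on tolerated concentration.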